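The source may hold more compounds than are shown below. What is called first, only, known or untested is meant among the compounds shown, and "the series" means these compounds.

Two thiourea compounds carrying a benzimidazole-bearing ring have been tested, and one more waits. Compound 1 `COc1ccc(C(=O)NC(=S)Nc2cccc(-c3nc4ccccc4[nH]3)c2)cc1OC` and compound 2 `Cc1ccc(-c2nc3ccccc3[nH]2)cc1NC(=S)NC(=O)c1ccc2c(c1)OCCO2` share a thiourea linked on one side to an amide and on the other to an aryl group. They were run in a functional assay on MDA-MB-231 cells (Homo sapiens) for cytotoxicity, read by WST assay, with a stated time of 48 h; a lower number here means a stronger inhibitor, a higher number a weaker inhibitor. Compound 1 reached only the limit of the assay, > 10000 nM, which is not a measured number; this is the same case as the limit of > 10000 nM in this assay, at which 1 of the 2 values shown sits. Among the compounds with values here, compound 2 gives 530 nM, the only actual number in this set, so it stands alone as the sole point of reference, with nothing measured either side of it.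

Compound 3 `Cc1ccc(-c2nc3ccccc3[nH]2)cc1NC(=S)NC(=O)c1ccccc1` has not yet been measured. It differs from compound 2 in one place: phenyl in place of 2,3-dihydro-1,4-benzodioxin-6-yl on a carbonyl carbon. Within the data shown here, no measured pair shows what this kind of change does here, so the expected size of the step rests on the change itself rather than on data. A modest loss of potency, possibly no larger than the usual scatter, is expected, giving a step of a 2.3-fold higher number from compound 2 to compound 3 (0.35 log units; beyond the scatter). Compound 3 is therefore estimated at 1200 nM, within a range from 300 nM to 5000 nM.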

Compound 3, half-maximal inhibitory concentration: > 10000 nM
Compound 3 gave a limit, no number (the forecaster's own chance of this, stated with the estimate: 20%); middle value at least 8.3-fold (0.92 log units) away from the limit.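

Within the data shown here, replacing 2,3-dihydro-1,4-benzodioxin-6-yl with phenyl on a carbonyl carbon is the first single change that can be read in this assay, and it gives an at least 18-fold higher number from compound 2 to compound 3 (1.27 log units; beyond the scatter). This large step, beyond the scatter, shows that the group at this place can decide whether the compound shows a measurable value in this pair, where the group with two oxygen atoms goes with the stronger result and plain phenyl does not. Compound 3 gives a limit rather than a number, so the full size of the step remains unknown, and this limit is now the most common result among the compounds shown: the limit of > 10000 nM in this assay, at which 2 of the 3 values shown sit.

This single pair cannot tell whether the oxygen atoms, the second ring or the larger size of 2,3-dihydro-1,4-benzodioxin-6-yl makes the difference. Also open, as far as these compounds go, is how this assay would respond to a phenyl carrying an amine or a carboxylic acid on this carbonyl carbon, or to a longer chain in place of the ring.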